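The source may report more compounds than this note shows. Statements on the series, on what has been measured and on what is new or still open speak of the compounds shown alone.

Compound 1 `COC(=O)/C(=C\c1ccc(OC(=O)c2cccc(OC)c2)cc1)Sc1ccnc2cc(Cl)ccc12` gives in an ADME assay on cells (Lymphocyte, Homo sapiens) for cytotoxicity, read by MTT assay, with a stated time of 48 h (on this read-out lower numbers stand for stronger inhibition and higher numbers for weaker inhibition), a value of > 100000 nM, which is a limit of the measurement rather than a number. Compound 2 `COC(=O)/C(=C\c1ccc(OC(=O)c2ccccc2OC)cc1)Sc1ccnc2cc(Cl)ccc12` likewise gives > 100000 nM, again only a limit. Compound 3 `COC(=O)/C(=C\c1ccc(OC(=O)c2cccc(OC)c2OC)cc1)Sc1ccnc2cc(Cl)ccc12` gives 86600 nM. The move a step that the two limits leave unreadable from compound 1 to compound 2 cannot be sized, while an at least 1.1-fold lower number from compound 1 to compound 3 (0.06 log units; that floor lies within the scatter) and an at least 1.1-fold lower number from compound 2 to compound 3 (0.06 log units; that floor lies within the scatter) each sit at a floor inside the scatter; the limit of > 100000 nM in this assay, at which 2 of the 3 values shown sit, is where compound 1 and compound 2 stand. Compound 4 `COC(=O)/C(=C\c1ccc(OC(=O)c2cc(OC)c(OC)cc2OC)cc1)Sc1ccnc2cc(Cl)ccc12` carries the change (2,4,5-trimethoxyphenyl in place of 3-methoxyphenyl on a carbonyl carbon). Every step seen so far among these methoxyphenyl variants stays within the scatter, so no step beyond the scatter is expected here either. Compound 4 is therefore expected to give 100000 nM, between 50000 nM and 200000 nM, most probably again as a limit. The expected step of a number no higher from compound 1 to compound 4 (the limit leaves the size open) thus means no change beyond the scatter.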

Compound 4, half-maximal inhibitory concentration: 52500 nM
Beside the measured number, compound 4's estimate is 1.9-fold (0.28 log units) above it, within the range that was stated.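

Going to 2,4,5-trimethoxyphenyl on this carbonyl carbon gives the first comparison between two measured numbers at this place in this assay: there is a 1.6-fold lower number from compound 3 to compound 4 (0.22 log units; within the scatter). Against the two compounds held at a limit, the series shows an at least 1.9-fold lower number from compound 1 to compound 4 (0.27 log units; that floor lies within the scatter) and an at least 1.9-fold lower number from compound 2 to compound 4 (0.27 log units; that floor lies within the scatter). Adding methoxy groups to this aryl ester has therefore produced no step shown to lie beyond the scatter.

As far as these compounds go, the full size of those last two steps stays open because each starts from a limit: the limit of > 100000 nM in this assay, at which 2 of the 4 values shown sit. Whether an amine or a carboxylic acid on this ring would move the number beyond the scatter also stays open.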